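Amide group variation, estimating compound 4

The source may report more compounds than this note shows. Statements on the series, on what has been measured and on what is new or still open speak of the compounds shown alone.

Going by the values given here, compound 2 `O=C(CCc1ccccc1)Nc1nnc(-c2ccc3c(c2)OCCO3)s1` holds the lowest of the three numbers measured so far: in a functional assay on HepG2 cells (Homo sapiens) for antiproliferative activity, read by MTT assay, with a stated time of 48 h (on this read-out higher numbers stand for an effect only at larger amounts of compound and lower numbers for an effect already at smaller amounts), compound 2 gives 15.3 ug/mL. Compound 3 `O=C(Nc1nnc(-c2ccc3c(c2)OCCO3)s1)c1ccc(Cl)nc1` gives 15.4 ug/mL, which is within the scatter of compound 2 (a 1.0-fold higher number from compound 2 to compound 3 (0.00 log units; within the scatter)). Compound 1 `O=C(Nc1nnc(-c2ccc3c(c2)OCCO3)s1)c1ccccc1` gives 34.8 ug/mL, and the two steps away from it were both modest: a 2.3-fold lower number from compound 1 to compound 2 (0.36 log units; beyond the scatter) and a 2.3-fold lower number from compound 1 to compound 3 (0.35 log units; beyond the scatter). Compound 4 `O=C(Nc1nnc(-c2ccc3c(c2)OCCO3)s1)c1ccncc1` differs from compound 2 as follows: pyridin-4-yl in place of phenethyl on a carbonyl carbon. Among the compounds with values here, no measured step covers this exact change. The 6-chloropyridin-3-yl compound 3 sits within scatter of compound 2, and both replacements of phenyl lowered the number from compound 1 by similar modest amounts. Compound 4 is therefore expected to stay close to compound 2, with a 1.3-fold higher number from compound 2 to compound 4 (0.12 log units; within the scatter), a step likely within the scatter. The estimate for compound 4 is 20 ug/mL, with a range from 9 ug/mL to 45 ug/mL.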

Compound 4, half-maximal effective concentration: > 100 ug/mL
Compound 4 ended at the assay's limit (the forecaster's own chance of this, stated with the estimate: 5%); middle value at least 5.0-fold (0.69 log units) away from the limit.
By their numbers in this assay, from the lowest: compounds 2 and 3 (each within the scatter of the next); then compound 1. At a limit, above all of these: compound 4.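

Compound 4 stands at a limit of this assay, so its value is not a number: the limit of > 100 ug/mL in this assay, at which 1 of the 4 values shown sits. A six-membered aromatic ring on this carbonyl carbon does not by itself keep the number low, since pyridin-4-yl gives an at least 6.5-fold higher number from compound 2 to compound 4 (0.81 log units; beyond the scatter), an at least 6.4-fold higher number from compound 3 to compound 4 (0.81 log units; beyond the scatter) and an at least 2.8-fold higher number from compound 1 to compound 4 (0.45 log units; beyond the scatter). A ring nitrogen alone does not account for the step either, as compound 3 also carries one and stands far from this limit.

Going by these compounds, whether the step follows the position of the ring nitrogen or the absence of chlorine stays open. Also open, on these data alone, is where pyridin-3-yl, 2-chloropyridin-4-yl or a 2-(pyridin-4-yl)ethyl chain would fall.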